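The source may hold more compounds than are shown below. What is called first, only, known or untested is meant among the compounds shown, and "the series" means these compounds.

The series shares one core, seen in compound 1 `COc1ccc(-c2cc3cc(C)ccc3c(N)n2)cc1OC`, compound 2 `COc1cc(OC)cc(-c2cc3cc(OC)c(OC)cc3c(N)n2)c1` and compound 3 `CN(C)c1cccc2c(N)nc(-c3ccccc3)cc12`. In a functional assay on SNB-19 cells (Homo sapiens) for cytotoxicity, read by sulforhodamine B assay (a higher number here means a weaker inhibitor, a lower number a stronger inhibitor), compound 1 gives 2150 nM. In this assay compound 2 gives 400 nM. For compound 3 the read-out in this assay is only a limit, > 10000 nM; this value stands at the limit of > 10000 nM in this assay, at which 1 of the 3 values shown sits. Among the compounds with values here, no two of the measured compounds differ in only one place, so no single step between them can be sized; the values of compound 1 and compound 2 are simply what the two show.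

Compound 4 `Cc1ccccc1-c1cc2c(N(C)C)cccc2c(N)n1` is the next compound, still to be tested in this assay. It differs from compound 3 by methyl in place of hydrogen on an aromatic carbon, ortho to a large group. Within the data shown here, because compound 3 gives only the limit > 10000 nM, no step from it can be measured, and a change of this size gives no ground to expect a number that differs from that limit by more than the usual scatter. Compound 4 is therefore expected at 15000 nM, in the range 4000 nM to 50000 nM. The expected step is a step that the limit leaves unreadable from compound 3 to compound 4, with a strong chance that only a limit is reported again.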

Compound 4, half-maximal inhibitory concentration: > 10000 nM
Compound 4 was reported as a limit; the forecaster's own chance of this, stated with the estimate: 70%; the middle value is on the limit's open side.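

In this assay, within the data shown here, compound 4 gives > 10000 nM, which is a limit, as is the reading for compound 3, so no step between compound 3 and compound 4 can be read. The series now stands as follows: the limit of > 10000 nM in this assay, at which 2 of the 4 values shown sit.

The compounds shown leave open whether the change from phenyl to 2-methylphenyl alters the read-out at all, and which single changes separate compound 1 and compound 2 from these limits.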